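A few compounds are considered here, and "the series" means these few. Any claim that something is new, unique, unknown or untested is made for them only; others in the source may bear on it.

Measured in a functional assay on A549 cells (Homo sapiens) for antiproliferative activity, read by MTT assay, with a stated time of 48 h; a lower number here means a stronger inhibitor, a higher number a weaker inhibitor:
- Compound 1 `CCCCCC1(O)C(=O)Nc2ccc(Nc3ccc(OC)cc3)cc21`: 8000 nM
- Compound 2 `CCCCC1(O)C(=O)Nc2ccc(Nc3ccc(C)cc3)cc21`: 7500 nM

The value of compound 2 lies within the usual scatter of the value of compound 1, so the two stand level. Compound 3 `CCCCCC1(O)C(=O)Nc2ccc(Nc3ccc(C)cc3)cc21` differs from compound 2 by one change: methyl in place of hydrogen on a saturated chain carbon, four bonds along the chain from a saturated ring carbon. Among the compounds with values here, no measured pair shows this change alone, so the data offer no direct guide. In this assay, no step beyond the scatter is expected, in either direction. The estimated step is small: a 1.1-fold lower number from compound 2 to compound 3 (0.03 log units; within the scatter). For compound 3 the expected value is 7000 nM, with an estimated range from 3500 nM to 14000 nM.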

Compound 3, half-maximal inhibitory concentration: 8100 nM
Compound 3: the middle estimate sits 1.2-fold (0.06 log units) below what was measured, and the stated range covers the measured number.
By their numbers in this assay, from the lowest: compounds 2, 1 and 3 (each within the scatter of the next).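

In this assay, methyl in place of hydrogen on a saturated chain carbon, four bonds along the chain from a saturated ring carbon, makes no step beyond the scatter (a 1.1-fold higher number from compound 2 to compound 3 (0.03 log units; within the scatter)). Methyl in place of methoxy on an aromatic carbon also stays within the scatter (a 1.0-fold higher number from compound 1 to compound 3 (0.01 log units; within the scatter)), so each of these two places now has one direct reading. No measured evidence bears on why these numbers stand level.

On these data alone, whether a much longer chain at the saturated carbon, or an amine or a carboxylic acid on the aromatic carbon, would shift the number remains open.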